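The source may hold more compounds than are shown below. What is called first, only, known or untested is meant among the compounds shown, and "the series" means these compounds.

Working notes on the series in a functional assay on isolated protein for inhibition of Glucose-dependent insulinotropic receptor (Rattus norvegicus), read by HTRF and cAMP accumulation; a lower number here means a smaller maximal response, a higher number a larger maximal response. Of the compounds shown here, two carry a number so far. Compound 1 `Cc1nc(S(C)(=O)=O)ccc1Oc1ncnc(OC2CCN(C(=O)C(F)(F)F)CC2)c1F` gives 76% in this assay. Compound 2 `Cc1nc(S(C)(=O)=O)ccc1Oc1ncnc(OC2CCN(C(=O)C3CCCC3)CC2)c1F` gives 83% in this assay. Within the data shown here, the one step between measured compounds is a number 7 percentage points higher from compound 1 to compound 2 (within the scatter), so the two numbers cannot be told apart, and compound 2 stands at the higher of two values only by a margin that the scatter covers.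

Compound 3 `Cc1nc(S(C)(=O)=O)ccc1Oc1ncnc(OC2CCN(C(=O)c3noc(C(C)(C)F)n3)CC2)c1F` is not yet measured. It differs from compound 2 at the carbonyl carbon whose other neighbours are an amide-type nitrogen in a ring: a group of 9 heavy atoms (5 carbon, 2 nitrogen, 1 oxygen, 1 fluorine; one five-membered aromatic ring with 3 hetero atoms) in place of a group of 5 heavy atoms (5 carbon; one five-membered non-aromatic ring of carbon only), on a carbonyl carbon

Among the measured compounds shown here, the only step that bears on this position is the exchange of trifluoromethyl for cyclopentyl on the same carbonyl carbon, which moved the maximal response by a margin within the scatter. For the measured compounds named here, no measured step shows what a five-membered aromatic ring with 3 hetero atoms does at this place, so there is no ground to expect a shift beyond the scatter in either direction.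

For compound 3 the expected efficacy in this assay is 80%, with a range of 65% to 93%. That estimate means a step of a number 3 percentage points lower from compound 2 to compound 3 (within the scatter), within the scatter.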

Compound 3, largest response reached (reported as efficacy), in percent of the reference or control that the assay uses: 74%
Estimate against measurement, compound 3: 6 percentage points above; the range from low to high includes it.
By their numbers in this assay, from the lowest: compounds 3, 1 and 2 (each within the scatter of the next).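

In this assay, the carbonyl carbon now has a third group, the fluorinated five-membered aromatic ring with 3 hetero atoms, and this exchange gives a number 9 percentage points lower from compound 2 to compound 3 (within the scatter), while the exchange for trifluoromethyl gives a number 2 percentage points lower from compound 1 to compound 3 (within the scatter). Among these compounds, for the first time, an aromatic ring and hydrogen-bond acceptors on this group are covered, and neither step separates the compounds, so trifluoromethyl, cyclopentyl and this larger group of 9 heavy atoms cannot be told apart by maximal response in these three compounds. No measurement is available that would explain this result.

From the compounds shown here alone, whether any group on this carbonyl carbon can move the maximal response beyond the scatter remains open, for example a primary amine, a carboxylic acid, a longer alkyl chain or a plain phenyl ring. Also open, going by these compounds, is whether the same indifference would hold with changes elsewhere in the shared core, since all three compounds differ only at this one place.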